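Oxime ether chain length against the antiproliferative limit

This account rests on a few compounds, and the source may have more. Where it says the series, first, only, none or still open, it means among the compounds named here.

In a functional assay on A549 cells (Homo sapiens) for antiproliferative activity (a higher number here means that more compound is needed for the effect, a lower number that less compound is needed), compound 2 `CCCCCC/C(=N\OC)c1cc(OC)c2c(c1OC)C(=O)C=CC2=O` gives > 10 ug/mL, which is a limit of the assay and not a number. Compound 1 `CCCCCCCCCCCCO/N=C(\CCCCCC)c1cc(OC)c2c(c1OC)C(=O)C=CC2=O` likewise reaches only the limit > 10 ug/mL in this assay. The step that the two limits leave unreadable from compound 1 to compound 2 is therefore unreadable, as the limit of > 10 ug/mL in this assay, at which 2 of the 2 values shown sit, shows. Compound 3 `CCCCCCCCCO/N=C(\CCCCCC)c1cc(OC)c2c(c1OC)C(=O)C=CC2=O` differs from compound 2 by octyl in place of hydrogen on a saturated chain carbon bound to an oxygen on an unsaturated carbon. Among the measured compounds shown here, no measured step on this series reads a size, so no direction beyond the scatter can be expected. Compound 3 is estimated at 20 ug/mL, between 8 ug/mL and 60 ug/mL, an expected step that the limit leaves unreadable from compound 2 to compound 3 and most likely again only a limit.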

Compound 3, concentration for half-maximal effect: > 10 ug/mL
Compound 3 gave a limit, no number (the forecaster's own chance of this, stated with the estimate: 80%); the middle value does not contradict the limit.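

Among the compounds shown here, compound 1, compound 2 and compound 3 all sit at an assay limit, so no step among them can be read: the limit of > 10 ug/mL in this assay, at which 3 of the 3 values shown sit. From the compounds shown here alone, whether oxime ether chain length has any effect in this assay stays open.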